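The source may report more compounds than this note shows. Statements on the series, on what has been measured and on what is new or still open speak of the compounds shown alone.

Measured so far in a functional assay on MDA-MB-231 cells (Homo sapiens) for antiproliferative activity, read by MTT assay, with a stated time of 48 h; a lower number here means a stronger inhibitor, a higher number a weaker inhibitor:
- compound 1 `CN1CCN(c2ccc(-c3cc4c(N5CCN(C(=O)Nc6ccccc6)CC5)ncnc4s3)cc2)CC1`: 7590 nM
- compound 2 `CN1CCN(c2ccc(-c3cc4c(N5CCN(C(=O)Nc6ccc(OC(F)(F)F)cc6)CC5)ncnc4s3)cc2)CC1`: 4600 nM

Among the compounds with values here, compound 2 stands within the scatter of the only other measured compound, so the two cannot be ranked. Compound 3 `CN1CCN(c2ccc(-c3cc4c(N5CCN(C(=O)Nc6ccccc6F)CC5)ncnc4s3)cc2)CC1` carries 2-fluorophenyl in place of 4-(trifluoromethoxy)phenyl on an amide-type nitrogen. Within the data shown here, one measured step bears on this change, since it alters the same phenyl group: a 1.7-fold lower number from compound 1 to compound 2 (0.22 log units; within the scatter). Among the measured compounds shown here, that step is small, and no measured step shows what a 2-fluorophenyl group does here. A step beyond the scatter in this assay is therefore not expected, in either direction. For compound 3 the estimated value is 6000 nM, with an expected range from 2800 nM to 13000 nM. The expected change is a 1.3-fold higher number from compound 2 to compound 3 (0.12 log units; within the scatter).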

Compound 3, half-maximal inhibitory concentration: 10300 nM
Beside the measured number, compound 3's estimate is 1.7-fold (0.23 log units) below it; the range from low to high includes it.
By their numbers in this assay, from the lowest: compounds 2, 1 and 3 (each within the scatter of the next, the first and the last beyond it).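

In this assay the phenyl group on the amide-type nitrogen now gives its first step beyond the scatter: 2-fluorophenyl in place of 4-(trifluoromethoxy)phenyl gives a 2.2-fold higher number from compound 2 to compound 3 (0.35 log units; beyond the scatter) as a modest step. Fluoro in place of hydrogen on an aromatic carbon gives a 1.4-fold higher number from compound 1 to compound 3 (0.13 log units; within the scatter) and stays within the scatter, so this fluoro group cannot be told apart from hydrogen here, and only the two compounds carrying substituted phenyl groups separate. Nothing available explains either step.

The compounds shown leave open how much of the wider step comes from removing trifluoromethoxy and how much from adding fluoro. As far as these compounds go, it also remains open what a chloro, methoxy or dimethylamino group would do on this phenyl ring.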